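The source may report more compounds than this note shows. Statements on the series, on what has been measured and on what is new or still open speak of the compounds shown alone.

Measured compounds in an assay on HEK293 cells for displacement of a labelled ligand from NPC1-like intracellular cholesterol transporter 1 (Homo sapiens); on this read-out higher numbers stand for weaker inhibition and lower numbers for stronger inhibition:
compound 1 `CC(C)(C)OC(=O)NCCNC(=O)CN1CN(c2ccccc2)C2(CCN(C(=O)c3ccc(C(C)(C)C)cc3)CC2)C1=O` gives 10900 nM
compound 2 `CCOC(=O)C1CCCN(C(=O)CN2CN(c3ccccc3)C3(CCN(C(=O)c4ccc(C(C)(C)C)cc4)CC3)C2=O)C1` gives 8200 nM
compound 3 `CC(C)(C)c1ccc(C(=O)N2CCC3(CC2)C(=O)N(CC(=O)NCN)CN3c2ccccc2)cc1` gives 26500 nM

Compound 3 stands at the highest number of the three. The steps up to it are a 2.4-fold higher number from compound 1 to compound 3 (0.39 log units; beyond the scatter) and a 3.2-fold higher number from compound 2 to compound 3 (0.51 log units; beyond the scatter); both lie beyond the scatter, so compound 3 is the weakest of the measured set. The step between compound 1 and compound 2, a 1.3-fold lower number from compound 1 to compound 2 (0.12 log units; within the scatter), lies within the scatter.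

Compound 4 `CC(C)(C)c1ccc(C(=O)N2CCC3(CC2)C(=O)N(CC(=O)N2CCCC(CO)C2)CN3c2ccccc2)cc1` differs from compound 3 in one place: 3-(hydroxymethyl)piperidin-1-yl in place of (aminomethyl)amino on a carbonyl carbon

Among the measured compounds shown here, the step that bears on this is the one from compound 2 to compound 3, where a 3-(ethoxycarbonyl)piperidin-1-yl was replaced by the small open-chain group and the number rose by a 3.2-fold higher number from compound 2 to compound 3 (0.51 log units; beyond the scatter). Compound 4 goes the opposite way, back to a piperidin-1-yl on the carbonyl carbon, with a hydroxymethyl in place of the ethoxycarbonyl. For the measured compounds named here, no measured pair shows what that exchange on the piperidine itself does. Going by the values given here, on the one relevant step, compound 4 is expected to come out with a lower number than compound 3, a step of about a 2.9-fold lower number from compound 3 to compound 4 (0.47 log units; beyond the scatter) in this assay. Compound 4 is therefore estimated at 9000 nM, with a range from 4000 nM to 20000 nM.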

Compound 4, half-maximal inhibitory concentration: 8200 nM
Compound 4: the middle estimate sits 1.1-fold (0.04 log units) above what was measured; the range from low to high includes it.
By their numbers in this assay, from the lowest: compounds 2, 4 and 1 (each within the scatter of the next); then compound 3.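

On this assay the exchange on the piperidine itself can now be read: hydroxymethyl in place of ethoxycarbonyl on a saturated ring carbon gives no change at the digits printed from compound 2 to compound 4 (within the scatter) and so leaves the number within the scatter. The return from (aminomethyl)amino to a substituted piperidin-1-yl on the carbonyl carbon gives a 3.2-fold lower number from compound 3 to compound 4 (0.51 log units; beyond the scatter) and is thus seen with a second piperidine substituent, while the open-chain (2-((tert-butoxycarbonyl)amino)ethyl)amino group stays level with the hydroxymethyl piperidine, at a 1.3-fold lower number from compound 1 to compound 4 (0.12 log units; within the scatter) and within the scatter, so a piperidine ring is not required to reach this level. No measurement at hand accounts for any of these steps.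

Open, on these data alone, is whether a carboxylic acid or an amine on the same saturated ring carbon would stay at this level. Also open, as far as these compounds go, is whether the unsubstituted piperidin-1-yl would sit with these compounds.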